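Methoxy groups in place of the amine on the carbonyl side

This account rests on a few compounds, and the source may have more. Where it says the series, first, only, none or still open, it means among the compounds named here.

Compound 1 `COc1cc(-c2cc(/C=C/C(=O)c3ccc(N)cc3)[nH]n2)cc(OC)c1OC`: -55%
Compound 2 `COc1ccc(-c2cc(/C=C/C(=O)c3ccc(OC)c(OC)c3)[nH]n2)cc1`: -40%
Compound 3 `COc1ccc(-c2cc(/C=C/C(=O)c3cc(OC)c(OC)c(OC)c3)[nH]n2)cc1OC`: -56%

The three compounds share one core and were tested in a functional assay on SF-268 cells (Homo sapiens) for cytotoxicity, read by sulforhodamine B assay, with a stated time of 48 h, tested at 10 uM; a higher number here means a weaker effect of the compound at the concentration tested, a lower number a stronger effect. In this assay compound 1 gives -55%, the second highest of the three numbers; compound 3 at -56% sits within the scatter of it, while compound 2 at -40% lies higher, beyond the scatter. Compound 4 `COc1ccc(C(=O)/C=C/c2cc(-c3cc(OC)c(OC)c(OC)c3)n[nH]2)cc1OC` differs from compound 1 in one place: 3,4-dimethoxyphenyl in place of 4-aminophenyl on a carbonyl carbon. For the measured compounds named here, no measured pair shows this exact change, so only the narrow spread of the three numbers guides the expectation. The step of a number 5 percentage points higher from compound 1 to compound 4 (within the scatter) is expected to stay within the scatter, with no clear direction. Compound 4 is therefore expected to give about -50%, between -70% and -30%.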

Compound 4, a percentage reported as activity, at one concentration (the size of the read-out at that concentration, not a potency): -60%
The estimate for compound 4 lay 10 percentage points above the measured number; low and high end bracket the measured number.
By their numbers in this assay, from the lowest: compounds 4, 3 and 1 (each within the scatter of the next); then compound 2.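

For the compounds shown here, replacing 4-aminophenyl with 3,4-dimethoxyphenyl on a carbonyl carbon gives a number 5 percentage points lower from compound 1 to compound 4 (within the scatter) in this assay and is the first direct one-place comparison at this position. In this single pair, the read-out stays within the scatter although the entering group has more heavy atoms and no hydrogen-bond donor. Nothing measured here gives a reason for this result. From the compounds shown here alone, whether 4-hydroxyphenyl or 4-carboxyphenyl at this place would also stay within the scatter of compound 1 remains open. A single concentration also leaves the potency of both compounds open.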